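Furan-3-yl for 1H-pyrazol-3-yl on the ethylamide side chain

The source may hold more compounds than are shown below. What is called first, only, known or untested is meant among the compounds shown, and "the series" means these compounds.

Measured so far:
- compound 1, `Cc1ccc(OCC(=O)N(Cc2cccs2)c2cccnc2)cc1`: 198 nM
- compound 2, `CCN(Cc1cc[nH]n1)C(=O)COc1ccc(C)cc1`: "not active" (no number reported)
- compound 3, `CCN(Cc1cccs1)C(=O)c1cc2cc(C)ccc2o1`: 120 nM

In an assay on HEK293 cells for agonist activity at transient receptor potential cation channel subfamily M member 8 (Homo sapiens), read by fluorescence and calcium flux, with a stated time of 15 min (a higher number here means that more compound is needed for the effect, a lower number that less compound is needed), compound 1 gives 198 nM and compound 3 gives 120 nM; the two values lie within the scatter of each other, so nothing separates them. For the measured compounds named here, compound 2 stands apart: in this assay compound 2 is reported as "not active" (no number reported), with no single number behind it, so it cannot be placed on the same scale as compound 1 or compound 3, and no step from compound 2 to any measured compound can be sized.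

Compound 4, `CCN(Cc1ccoc1)C(=O)COc1ccc(C)cc1`, is not yet measured. It differs from compound 2 in one place:

furan-3-yl in place of 1H-pyrazol-3-yl on a saturated chain carbon bound to an amide-type nitrogen

Going by the values given here, no measured pair carries this change, so its size in this assay is open. Compound 1 and compound 3 both carry a five-membered aromatic ring with one hetero atom on the saturated chain carbon bound to the amide-type nitrogen and both give a number, whereas compound 2 carries the 1H-pyrazol-3-yl and gives none. On that ground compound 4 is expected to return a measurable value, most likely weaker than compound 1 and compound 3, with a real chance that it again comes back without a number. The estimate for compound 4 in this assay is 1500 nM, between 300 nM and 10000 nM.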

Compound 4, half-maximal effective concentration: 136 nM
Compound 4: middle estimate off by 11-fold (1.04 log units), on the high side; the measured number lies below the stated range.
By their numbers in this assay, from the lowest: compounds 3, 4 and 1 (each within the scatter of the next).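

No new step can be read: compound 2 has no number, so its difference from compound 4 at 136 nM cannot be sized. No measured evidence bears on this result. The compounds shown leave open how large the change from 1H-pyrazol-3-yl to furan-3-yl is when both partners give a number.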